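The source may hold more compounds than are shown below. What is called first, only, known or untested is meant among the compounds shown, and "the series" means these compounds.

Compound 3 (`OC[C@H]1O[C@@H](n2cnc3c(NCc4cc(O)cc(O)c4)ncnc32)[C@H](O)[C@@H]1O`) gives > 166000 nM in a functional assay on G-361 cells (Homo sapiens) for antiproliferative activity, with a stated time of 72 h (on this read-out higher numbers stand for weaker inhibition and lower numbers for stronger inhibition), and this is a limit, not a number. Compound 1 (`OC[C@H]1O[C@@H](n2cnc3c(NCc4ccc(Cl)cc4)ncnc32)[C@H](O)[C@@H]1O`) gives > 166000 nM in this assay and this too is a limit. Compound 2 (`COc1cc(CNc2ncnc3c2ncn3[C@@H]2O[C@H](CO)[C@@H](O)[C@H]2O)cc(OC)c1`) carries the entry "not determined" (no result reported) in this assay and adds nothing to the comparison. The evidence so far is therefore the limit of > 166000 nM in this assay, at which 2 of the 3 values shown sit, and no measured number stands beside it.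

Going to compound 4 (`Cc1cccc(CNc2ncnc3c2ncn3[C@@H]2O[C@H](CO)[C@@H](O)[C@H]2O)c1O`) puts 2-hydroxy-3-methylphenyl in place of 3,5-dihydroxyphenyl on a saturated chain carbon bound to a nitrogen on an aromatic ring. Among the measured compounds shown here, the one measured step is a step that the two limits leave unreadable from compound 1 to compound 3 and it offers no size to carry over. Any readable change from compound 3 can only run towards stronger inhibition, and another limit remains quite possible. The expected size is an at least 5.5-fold lower number from compound 3 to compound 4 (0.74 log units; beyond the scatter) in the direction of stronger inhibition, held loosely for lack of any readable step. For compound 4 the estimated value is 30000 nM with an expected range from 2000 nM to 166000 nM in this series.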

Compound 4, half-maximal inhibitory concentration: > 166000 nM
Compound 4 gave a limit, no number; the forecaster's own chance of this, stated with the estimate: 50%; at least 5.5-fold (0.74 log units) between middle value and limit.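

Among the compounds shown here, compound 1, compound 3 and compound 4 each give only a limit in this assay, so no step among them can be read. The compounds shown leave open whether any group at this place gives a measured number, and how these groups compare: the limit of > 166000 nM in this assay, at which 3 of the 4 values shown sit.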